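Adding a dimethylaminopropyl chain to compound 2

This account rests on a few compounds, and the source may have more. Where it says the series, first, only, none or still open, it means among the compounds named here.

Values in an ADME assay on MDBK cells (Bos taurus) for cytotoxicity, read by MTT assay, with a stated time of 96 h (a higher number here means that more compound is tolerated, a lower number that less compound is tolerated), for the half-maximal cytotoxic concentration:
Compound 1 `Fc1ccc(F)c(/N=N/N2CCCC2)c1` at > 100000 nM (a limit)
Compound 2 `Fc1ccc(F)c(/N=N/Nc2ccccc2)c1` at > 100000 nM (a limit)
Compound 3 `Fc1ccc(F)c(/N=N/Nc2cccc(C(F)(F)F)c2)c1` at > 100000 nM (a limit)

Compound 2 gives > 100000 nM and that is a limit only. Among the measured compounds shown here, the series so far offers the limit of > 100000 nM in this assay, at which 3 of the 3 values shown sit, and no number. Compound 4 `CN(C)CCCN(/N=N/c1cc(F)ccc1F)c1ccccc1` carries 3-(dimethylamino)propyl in place of hydrogen on a nitrogen on an aromatic ring, counted as 3-(dimethylamino)propyl in place of hydrogen on a nitrogen on an aromatic ring in full. For the measured compounds named here, the one measured step that bears on this is a step that the two limits leave unreadable from compound 2 to compound 3 and it gives no size to carry over. None of compounds 1 to 3 has such a chain, so the expectation is weakly held and rests on the structural change alone. Estimated is an at least 1.6-fold lower number from compound 2 to compound 4 (0.22 log units; that floor lies within the scatter) with less compound tolerated, and a reading at the limit again remains quite possible. In this assay compound 4 is estimated at 60000 nM with an expected range from 20000 nM to 100000 nM as its two ends.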

Compound 4, half-maximal cytotoxic concentration: 25000 nM
Beside the measured number, compound 4's estimate is 2.4-fold (0.38 log units) above it, and the stated range covers the measured number.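

Among the compounds shown here, the nitrogen on an aromatic ring is the first place where a change gives a readable result in this assay: 3-(dimethylamino)propyl in place of hydrogen gives an at least 4.0-fold lower number from compound 2 to compound 4 (0.60 log units; beyond the scatter). Compound 4 alone has a number, and the other compounds remain at a limit: the limit of > 100000 nM in this assay, at which 3 of the 4 values shown sit. From the compounds shown here alone, as compound 2 has only a limit, the step gives a floor and its full size remains unknown, but the floor already shows that this position is not silent in this assay.

Going by these compounds, it remains open whether the lower number follows the terminal dimethylamino group, the propyl chain or the loss of the hydrogen on that nitrogen, which a plain propyl group at the same place could help to separate. Also open, on these data alone, is whether the same chain has a comparable effect on compound 3, with its trifluoromethyl group.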